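From methoxy to fluoro: notes on compound 3

This account rests on a few compounds, and the source may have more. Where it says the series, first, only, none or still open, it means among the compounds named here.

Values in a functional assay on HCT-116 cells (Homo sapiens) for antiproliferative activity, read by CCK-8 assay, with a stated time of 72 h; a higher number here means a weaker inhibitor, a lower number a stronger inhibitor:
- compound 1 `Nc1ccccc1NC(=O)c1ccc(COc2ccc([N+](=O)[O-])cc2)cc1`: > 32000 nM (a limit)
- compound 2 `COc1ccc(OCc2ccc(C(=O)Nc3ccccc3N)cc2)cc1`: 2020 nM

For the measured compounds named here, compound 2, at 2020 nM, holds the only actual number so far. Compound 1 gives > 32000 nM, which is a limit.

Compound 3 `Nc1ccccc1NC(=O)c1ccc(COc2ccc(F)cc2)cc1` carries fluoro in place of methoxy on an aromatic carbon, para to a large group: fluoro in place of methoxy on an aromatic carbon. Going by the values given here, the one measured step bearing on this is an at least 15-fold lower number from compound 1 to compound 2 (1.19 log units; beyond the scatter), a large step with methoxy in place of nitro, and it includes no fluoro compound. In this assay a much smaller step to a higher number is therefore expected, possibly not beyond the scatter. The expected change is a 1.5-fold higher number from compound 2 to compound 3 (0.17 log units; within the scatter). For compound 3 the estimated value is 3000 nM, with an expected range of 1000 nM to 10000 nM.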

Compound 3, half-maximal inhibitory concentration: 3860 nM
Compound 3: the middle estimate sits 1.3-fold (0.11 log units) below what was measured; the measured number falls inside the stated range.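

On this aromatic carbon, para to a large group, fluoro in place of methoxy gives a 1.9-fold higher number from compound 2 to compound 3 (0.28 log units; within the scatter) in this assay and so does not separate the two groups, now with actual numbers at both ends. Fluoro in place of nitro gives an at least 8.2-fold lower number from compound 1 to compound 3 (0.91 log units; beyond the scatter) and shows that the large step away from nitro is not confined to methoxy. Compound 1 holds a limit, not a number: the limit of > 32000 nM in this assay, at which 1 of the 3 values shown sits.

On these data alone, how an amine or a carboxylic acid would read on this carbon stays open. So does whether any group here moves beyond the scatter from compound 2.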